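The source may hold more compounds than are shown below. What is called first, only, known or untested is meant among the compounds shown, and "the series" means these compounds.

Of the compounds shown here, three that share one core have been tested in a functional assay for antagonist activity at 5-hydroxytryptamine receptor 4 (Rattus norvegicus); a higher number here means a more potent compound, by a factor of ten per unit of this negative logarithm, a lower number a less potent compound. Compound 1 `CCOc1cc(N)c(Cl)cc1C(=O)CCCCN1CCCCC1` is the simplest of them. In this assay compound 1 gives only a limit, < 7, which is the limit of < 7 in this assay, at which 1 of the 3 values shown sits. Compound 2 `COc1ccc(COc2cc(N)c(Cl)cc2C(=O)CCCCN2CCCCC2)cc1OC` differs from compound 1 in a single place, and in this assay compound 2 gives 8.5; the step of a number at least 1.50 log units higher from compound 1 to compound 2 (beyond the scatter) is large. Compound 3 `COc1cc(COc2cc(N)c(Cl)cc2C(=O)CCCCN2CCC(c3ccccc3)CC2)cc(OC)c1` carries an extra group on the saturated ring with nitrogen, and in this assay compound 3 gives 7.7. Of the two numbers in hand, compound 3 stands lowest; the nearer value is that of compound 2, which lies higher by a gap beyond the usual scatter.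

Compound 4 `COc1cc(COc2cc(N)c(Cl)cc2C(=O)CCCCN2CCC(NS(C)(=O)=O)CC2)cc(OC)c1` differs from compound 3 only by methanesulfonamido in place of phenyl on a saturated ring carbon. Going by the values given here, no measured step touches that place: the one measured step, a number at least 1.50 log units higher from compound 1 to compound 2 (beyond the scatter), concerns the group on the oxygen of the aromatic ring, so it says little about a change on the saturated ring. Among the compounds with values here, with no comparable step to lean on, compound 4 is expected to sit close to compound 3, and the expected step of a number 0.20 log units lower from compound 3 to compound 4 (within the scatter) is small. Compound 4 is therefore estimated to give 7.5 in this assay, with a range from 6.8 to 8.3.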

Compound 4, negative logarithm of the antagonist equilibrium constant: 8.4
Beside the measured number, compound 4's estimate is 0.90 log units below it, and the stated range ends below it.
By their numbers in this assay, from the lowest: compound 3; then compounds 4 and 2 (each within the scatter of the next). At a limit, below all of these: compound 1.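

Changing the group on this saturated ring carbon, three ring bonds from the ring nitrogen, gives a step of a number 0.70 log units higher from compound 3 to compound 4 (beyond the scatter), so the group held here matters in this assay. Going by these compounds alone, this is the first measured change at this place, and it shows that an aromatic ring is not needed there for this pair: phenyl, an aromatic ring of carbon only, leaves, and methanesulfonamido, with no ring, 1 hydrogen-bond donor and 2 hydrogen-bond acceptors, enters, and the number rises. Within the data shown here, nothing measured so far says which of these differences lies behind the step.

Other groups on the same ring carbon would be needed to pull these differences apart: cyclohexyl would keep a ring of carbon without the aromatic ring, while acetamido would keep the nitrogen with a carbonyl in place of the sulfur and its oxygens, and a plain amine would keep only the nitrogen. On these data alone, it also remains open whether the same exchange of phenyl for methanesulfonamido would give a similar step with the 3,4-dimethoxyphenyl group of compound 2 on the aromatic ring's oxygen.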